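Swapping the aryl group on a seven-membered ring

The source may hold more compounds than are shown below. What is called first, only, known or untested is meant among the compounds shown, and "the series" means these compounds.

Compound 1 `COc1cc2c(cc1OC)C(c1cccc(N)c1)=NN=C(S)C2` and compound 2 `COc1cc2c(cc1OC)C(c1ccc(Cl)cc1)=NN=C(S)C2` share one core and differ only in the aryl group attached to it. In a functional assay on the whole organism with Mus musculus as the target (on this read-out lower numbers stand for an effect already at smaller amounts and higher numbers for an effect only at larger amounts of compound), compound 1 gives 9.1 umol/kg, and compound 2 gives 55 umol/kg. The change between them is 3-aminophenyl in place of 4-chlorophenyl on a carbon with a double bond to nitrogen and it made the step of a 6.0-fold lower number from compound 2 to compound 1 (0.78 log units; beyond the scatter). Compound 3 `COc1cc2c(cc1OC)C(c1ccc(Cl)cc1)=NNC(=O)C2` carries the same 4-chlorophenyl as compound 2 but sits on a different core; the difference between the two cores is not broken down here. In this assay compound 3 gives 75.3 umol/kg, which lies within the scatter of compound 2. Compound 4 `COc1cc2c(cc1OC)C(c1cccc(N)c1)=NNC(=O)C2` has not yet been measured. Its difference from compound 3 is 3-aminophenyl in place of 4-chlorophenyl on a carbon with a double bond to nitrogen. Among the compounds with values here, this is the same kind of change as the one from compound 2 to compound 1, though the surroundings are not identical: in compound 2 the place also lies three ring bonds from the ring atom that bears a sulfanyl group (1 heavy atom), a feature that compound 3 lacks. If the change carries over, compound 4 is expected to show a step of about a 5.8-fold lower number from compound 3 to compound 4 (0.76 log units; beyond the scatter) in this assay. That expectation rests on the step of a 6.0-fold lower number from compound 2 to compound 1 (0.78 log units; beyond the scatter) and on compound 3 giving 75.3 umol/kg. Compound 4 is therefore estimated at 13 umol/kg in this assay, with a range from 5 umol/kg to 35 umol/kg; the band is wide, as the change has been seen only once and on a different core.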

Compound 4, dose for half-maximal effect: 18.3 umol/kg
Compound 4: the middle estimate sits 1.4-fold (0.15 log units) below what was measured; the measured number falls inside the stated range.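

In this assay, within the data shown here, the swap from 4-chlorophenyl to 3-aminophenyl on the second core gives a 4.1-fold lower number from compound 3 to compound 4 (0.61 log units; beyond the scatter), which is the same direction as on the first core, the one bearing the sulfanyl group. The two steps can be treated as one effect of similar size, since the gap between them is no larger than repeated measurements would be expected to produce: the same change on two cores in this assay, a 6.0-fold lower number (0.78 log units; beyond the scatter) from compound 2 to compound 1 and a 4.1-fold lower number (0.61 log units; beyond the scatter) from compound 3 to compound 4, 1.5-fold (0.17 log units) apart, within the scatter of two such steps This supports carrying the swap between these two cores, but it rests on just two matched pairs, so it does not show that the swap would work on any other core, and it does not explain why the number falls.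

Each swap removes the chlorine and brings in the amine in a single move, so the compounds shown cannot tell whether losing one or gaining the other drives the step, and a plain phenyl group would be needed to begin separating the two. Also open, as far as these compounds go, is how this assay would respond to other groups in the same place, such as a hydroxyl group, a carboxylic acid or an amine on a longer chain.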